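Swapping the aryl group on the longest compound

The source may hold more compounds than are shown below. What is called first, only, known or untested is meant among the compounds shown, and "the series" means these compounds.

Measured in a functional assay on MIA PaCa-2 cells (Homo sapiens) for inhibition, read by MTT assay, with a stated time of 72 h (on this read-out higher numbers stand for weaker inhibition and lower numbers for stronger inhibition), so far:
- compound 1 `COc1cc(NC(C)CCCNC(=O)Nc2ccc(F)cc2)c2ncccc2c1` gives 21000 nM
- compound 2 `COc1cc(NC(C)CCCNC(=O)Nc2ccc(C(F)(F)F)cc2)c2ncccc2c1` gives 8400 nM
- compound 3 `COc1cc(NC(C)CCCNC(=O)NNC(=O)Nc2cccc(Cl)c2)c2ncccc2c1` gives 74000 nM

Compound 3 has the highest number of the three and is the weakest inhibitor of this set. Its distance from the others shows in a 3.5-fold higher number from compound 1 to compound 3 (0.55 log units; beyond the scatter) and in an 8.8-fold higher number from compound 2 to compound 3 (0.94 log units; beyond the scatter) and both steps are beyond the scatter.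

Compound 4 `COc1cc(NC(C)CCCNC(=O)NNC(=O)Nc2ccc(O)cc2)c2ncccc2c1` differs from compound 3 in one group, with 4-hydroxyphenyl in place of 3-chlorophenyl on an amide-type nitrogen is the whole of the change.

The two steps to compound 3 replace a much larger piece, so they bear on this change only weakly. The closest measured change is trifluoromethyl in place of fluoro on an aromatic carbon, which gave a 2.5-fold lower number from compound 1 to compound 2 (0.40 log units; beyond the scatter) and counts as modest. For the measured compounds named here, no measured compound carries a hydroxy group, so the direction has little support. A change of about that size is the most that is expected in this assay and a smaller one seems more likely.

The expected step is a 1.2-fold higher number from compound 3 to compound 4 (0.09 log units; within the scatter) and would leave the number close to where it stands. The estimate for compound 4 is 90000 nM with an expected range from 35000 nM to 220000 nM on this read-out.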

Compound 4, half-maximal inhibitory concentration: 142000 nM
For compound 4 the middle estimate is 1.6-fold (0.20 log units) below the measured one; low and high end bracket the measured number.
By their numbers in this assay, from the lowest: compound 2; then compound 1; then compounds 3 and 4 (each within the scatter of the next).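

In this assay, the exchange of 3-chlorophenyl for 4-hydroxyphenyl on the amide-type nitrogen gives a 1.9-fold higher number from compound 3 to compound 4 (0.28 log units; within the scatter) and stays within the scatter, so this position accepts a second aryl group, with chlorine leaving and a hydroxy group entering, without a readable shift in the number. The higher numbers of the longer compounds therefore no longer rest on compound 3 alone, since compound 4 shows the same gap to the shorter ureas, with a 17-fold higher number from compound 2 to compound 4 (1.23 log units; beyond the scatter) as a large step and a 6.8-fold higher number from compound 1 to compound 4 (0.83 log units; beyond the scatter) as a modest one. Within the longer pair, the aryl swap reads as much smaller than the replacement of the whole piece on the amide-type nitrogen, and in this set it is that larger replacement that separates the compounds.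

As far as these compounds go, it remains open whether an amine or a carboxylic acid on the aryl ring, or a longer chain in place of the ((3-chlorophenyl)carbamoyl)amino piece, would move the number out of this range. Nothing given here accounts for the size or direction of these steps.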